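Pyridin-3-yl in Place of Methanesulfonamido on the Shared Core

The source may report more compounds than this note shows. Statements on the series, on what has been measured and on what is new or still open speak of the compounds shown alone.

Compound 1, `c1cc(-c2ccn[nH]2)c2c(c1)C(c1ncc[nH]1)CC2`: 336 nM
Compound 2, `c1ccc2c(c1)CCC2c1ncc[nH]1`: > 10000 nM
Compound 3, `CS(=O)(=O)Nc1cccc2c1CCC2c1ncc[nH]1`: > 10000 nM

In a functional assay on CHO cells for agonist activity at Alpha-1D adrenergic receptor (Homo sapiens), read by FLIPR and calcium flux (on this read-out lower numbers stand for an effect already at smaller amounts and higher numbers for an effect only at larger amounts of compound), compound 1 gives 336 nM. Compound 2 gives > 10000 nM, which is a limit of the assay and not a number. Compound 3 likewise gives only a limit, > 10000 nM. Compound 3 therefore stands at the limit of > 10000 nM in this assay, at which 2 of the 3 values shown sit, and the step that the two limits leave unreadable from compound 2 to compound 3 cannot be read. What can be read are the two steps from compound 1: an at least 29-fold higher number from compound 1 to compound 2 (1.47 log units; beyond the scatter) and an at least 29-fold higher number from compound 1 to compound 3 (1.47 log units; beyond the scatter).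

Compound 4, `c1cncc(-c2cccc3c2CCC3c2ncc[nH]2)c1`, is not yet measured. It differs from compound 3 by pyridin-3-yl in place of methanesulfonamido on an aromatic carbon. The group that enters is an aromatic ring, as the 1H-pyrazol-5-yl of compound 1 is, while the methanesulfonamido and the hydrogen of compounds 3 and 2 are not. Since the steps from compound 1 to compound 2 and to compound 3 were both large losses, the return of an aromatic ring at that position is expected to bring compound 4 back toward the region of compound 1, a step of about an at least 16-fold lower number from compound 3 to compound 4 (1.22 log units; beyond the scatter) in the direction of smaller numbers. Compound 4 is therefore estimated at 600 nM in this assay, within a range from 100 nM to 5000 nM.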

Compound 4, half-maximal effective concentration: > 10000 nM
Compound 4 was reported as a limit; the forecaster's own chance of this, stated with the estimate: 20%; at least 16-fold (1.22 log units) between middle value and limit.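

In this assay compound 4 gives > 10000 nM, which is a limit of the assay and not a number. An aromatic ring on this aromatic carbon is therefore not enough in itself to give a readable value, as the exchange of 1H-pyrazol-5-yl for pyridin-3-yl shows with an at least 29-fold higher number from compound 1 to compound 4 (1.47 log units; beyond the scatter), and among the four compounds shown only compound 1, with its 1H-pyrazol-5-yl, gives a value that is not a limit. The steps to compound 4 from compound 2 and from compound 3 cannot be read, and compound 4 stands with those two compounds at the same limit: the limit of > 10000 nM in this assay, at which 3 of the 4 values shown sit.

The compounds shown leave open whether the effect of compound 1 is tied to the 1H-pyrazol-5-yl itself or would also appear with another five-membered aromatic ring, such as 1H-imidazol-2-yl or thiazol-2-yl, or with an aminomethyl group at this place. They also leave open how compound 2, compound 3 and compound 4 rank against one another, since no order can be taken from their limits.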